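Oxetan-3-yl for Methyl: Expected Effect on Potency

This account rests on a few compounds, and the source may have more. Where it says the series, first, only, none or still open, it means among the compounds named here.

Compound 1 `Cn1c(CN2CCN(c3ccccc3NC(=O)c3ccco3)CC2)nc2ccccc21` gives 372 nM in a functional assay on CHO-K1 cells for antagonist activity at C-X-C chemokine receptor type 3 (Homo sapiens), read by FLIPR, with a stated time of 10 min; a lower number here means a stronger inhibitor, a higher number a weaker inhibitor.
Compound 2 `Cc1nc(-c2nc3ccccc3[nH]2)c(N2CCN(C(=O)Cn3cnc4cccnc43)[C@H](C)C2)s1` gives 9 nM in this assay.

Of the two measured compounds, compound 2 stands at the lower number, and compound 1 lies well above it, beyond the usual scatter. Compound 3 `C[C@@H]1CN(c2sc(C3COC3)nc2-c2nc3ccccc3[nH]2)CCN1C(=O)Cn1cnc2cccnc21` is the unmeasured member of the set. It differs from compound 2 in one place: oxetan-3-yl in place of methyl on an aromatic carbon. No pair of measured compounds isolates this exchange, so its size cannot be read from the data shown. Given that the rest of compound 3 is unchanged from compound 2, a modest step is expected, either none beyond the scatter or a small move toward a higher number, written here as a 1.8-fold higher number from compound 2 to compound 3 (0.25 log units; within the scatter). Compound 3 is therefore estimated at 16 nM in this assay, within a range from 4 nM to 60 nM.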

Compound 3, half-maximal inhibitory concentration: 53 nM
Compound 3: the middle estimate sits 3.3-fold (0.52 log units) below what was measured, and the stated range covers the measured number.
By their numbers in this assay, from the lowest: compound 2; then compound 3; then compound 1.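

The exchange of methyl for oxetan-3-yl, on the aromatic carbon next to the ring nitrogen and next to the ring sulfur, now has a measured size in this assay: it amounts to a 5.9-fold higher number from compound 2 to compound 3 (0.77 log units; beyond the scatter). This position therefore responds to the change, yet it takes the larger group with its four-membered ring, and compound 3 still gives 53 nM. No measurement of any property of these groups bears on the step, and its origin remains unexplained.

The compounds shown hold only methyl and oxetan-3-yl at this place, so it remains open whether the step follows the number of heavy atoms, the ring or the ring oxygen. Ethyl, cyclobutyl and tetrahydrofuran-3-yl at the same carbon would help to separate these three features.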